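Swapping Phenyl for Pyridin-2-yl on a Piperazine Nitrogen

The compounds below may be only part of what the source reports. "The series", "measured", "known", "first", "only" and "open" are said of these compounds alone.

The series shares one core carrying an aryl group on an aromatic carbon and a substituted piperazine at the end of a three-carbon chain. Compound 1 `CC(C)(C)c1ccc(-c2nnc(SCCCN3CCN(c4ccccc4)CC3)[nH]2)cc1`, measured in a functional assay on U-937 cells (Homo sapiens) for cytotoxicity, read by MTT assay, with a stated time of 24 h (a higher number here means a weaker inhibitor, a lower number a stronger inhibitor), gives 49300 nM. For compound 2 `Clc1ccc(-c2nnc(SCCCN3CCN(c4cccc(Cl)c4)CC3)[nH]2)cc1` this assay reports only a limit, > 300000 nM. For compound 3 `Cc1cccc(-c2nnc(SCCCN3CCN(c4ccccc4)CC3)[nH]2)c1` this assay likewise reports only a limit, > 300000 nM. Among the compounds with values here, the one step that can be sized, an at least 6.0-fold higher number from compound 1 to compound 3 (0.78 log units; beyond the scatter), runs onto that limit, so compound 3 stands among the weakest values shown, at the bound where two of three compounds sit (the limit of > 300000 nM in this assay, at which 2 of the 3 values shown sit).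

Compound 4 `Cc1cccc(-c2nnc(SCCCN3CCN(c4ccccn4)CC3)[nH]2)c1` differs from compound 3 only in the piperazine substituent: pyridin-2-yl in place of phenyl on an amine nitrogen in a ring. Within the data shown here, no measured step touches this position, and the only sized step concerns the aryl group on the core. There is thus no basis for expecting movement off the limit, in either direction, beyond the scatter. The expected step of a number no higher from compound 3 to compound 4 (the limit leaves the size open) is therefore essentially none. Compound 4 is estimated at 300000 nM, with a range from 150000 nM to 600000 nM.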

Compound 4, half-maximal inhibitory concentration: 52300 nM
The estimate for compound 4 lay 5.7-fold (0.76 log units) above the measured number; the whole stated range lies above it.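

The earlier compounds shown here offered no sized step at the piperazine substituent, and this result supplies one. In this assay, pyridin-2-yl in place of phenyl on an amine nitrogen in a ring gives an at least 5.7-fold lower number from compound 3 to compound 4 (0.75 log units; beyond the scatter), so this position can move the number off the limit even with 3-methylphenyl on the core. The true size of the step stays open, since the value of compound 3 is a limit and not a number: the limit of > 300000 nM in this assay, at which 2 of the 4 values shown sit.

Whether the ring nitrogen or its added hydrogen-bond acceptor accounts for the step is not settled by this single pair, and pyridin-3-yl or pyrimidin-2-yl on the same nitrogen could test this. Also open, going by these compounds, is whether pyridin-2-yl lowers the number in the same way with 4-(tert-butyl)phenyl on the core.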